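Replacing the Side Chain on the Aromatic Oxygen

A few compounds are considered here, and "the series" means these few. Any claim that something is new, unique, unknown or untested is made for them only; others in the source may bear on it.

In an ADME assay on microsomes from liver (Homo sapiens) for metabolic stability, read by LC-MS, tested at 1 uM (on this read-out lower numbers stand for slow clearance and higher numbers for fast clearance), compound 1 (`O=S(=O)(c1ccc([C@H]2CC[C@]3(CC2)OOC2(O3)C3CC4CC(C3)CC2C4)cc1)N1CCNCC1`) gives 16 mL.min-1.g-1 and compound 2 (`c1cc([C@H]2CC[C@]3(CC2)OOC2(O3)C3CC4CC(C3)CC2C4)ccc1OCCCNC1CCOCC1`) gives 10 mL.min-1.g-1. These two numbers lie within the scatter of each other, so compound 2 holds no separate place in this small set. Compound 3 (`N[C@H]1CC[C@H](Oc2ccc([C@H]3CC[C@]4(CC3)OOC3(O4)C4CC5CC(C4)CC3C5)cc2)CC1`) keeps the shared core and the aromatic oxygen of compound 2 but carries a different group there: 4-aminocyclohexyl in place of 3-((oxan-4-yl)amino)propyl on an oxygen on an aromatic ring. In short, 4-aminocyclohexyl stands in place of 3-((oxan-4-yl)amino)propyl on an oxygen on an aromatic ring.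

For the measured compounds named here, only one measured step bears on this change, and only loosely. The step of a 1.6-fold lower number from compound 1 to compound 2 (0.20 log units; within the scatter) exchanges (piperazin-1-yl)sulfonyl for 3-((oxan-4-yl)amino)propoxy on an aromatic carbon and stays within the scatter. Going by the values given here, no measured compound carries the entering group, so the data offer no direct precedent for it. With that single step as the guide, no shift beyond the scatter is expected in this assay. The expected step is a 1.2-fold higher number from compound 2 to compound 3 (0.08 log units; within the scatter). For compound 3 the estimated value is 12 mL.min-1.g-1, with an expected range of 6 mL.min-1.g-1 to 24 mL.min-1.g-1.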

Compound 3, intrinsic clearance in microsomes: < 7 mL.min-1.g-1
Compound 3: no number, only a limit (the forecaster's own chance of this, stated with the estimate: 5%); middle value at least 1.7-fold (0.23 log units) from the limit.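

In this assay compound 3 gives < 7 mL.min-1.g-1, which is a limit of the assay and not a number. With 4-aminocyclohexyl in place of 3-((oxan-4-yl)amino)propyl on an oxygen on an aromatic ring, the change gives an at least 1.4-fold lower number from compound 2 to compound 3 (0.15 log units; that floor lies within the scatter), so this floor alone does not separate the two side chains. The comparison with the sulfonyl-bearing compound does clear the scatter, with an at least 2.2-fold lower number from compound 1 to compound 3 (0.35 log units; beyond the scatter), which the earlier step in this set did not do, and the lowest reading of the set now rests on a limit: the limit of < 7 mL.min-1.g-1 in this assay, at which 1 of the 3 values shown sits.

As far as these compounds go, how far compound 3 truly lies under that limit stays open, and with it the real size of both steps. Also open, from the compounds shown here alone, is whether the gain, if there is one, follows the cyclohexyl ring or the amine on it, a question that a hydroxyl or an acetamide in place of the amine on the ring, or a plain propyl chain ending in a primary amine on the same oxygen, would bear on in this assay.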